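Removing the bromine from compound 2 in the tryptophan dioxygenase assay

A few compounds are considered here, and "the series" means these few. Any claim that something is new, unique, unknown or untested is made for them only; others in the source may bear on it.

Of the compounds shown here, three have been measured in an assay for inhibition of Tryptophan 2,3-dioxygenase (Homo sapiens), with stated times of 10 min and 60 min, tested at 100 uM; a lower number here means a weaker effect, a higher number a stronger effect of the compound at the concentration tested. Compound 1 `NCCn1ncc2c(NCc3ccccc3[N+](=O)[O-])cc(C(F)(F)F)cc21` gives 29%, compound 2 `O=[N+]([O-])c1ccccc1CNc1cc(Br)cc2[nH]ncc12` gives 64%, and compound 3 `O=[N+]([O-])c1ccc(O)cc1CNc1cc(Br)cc2[nH]ncc12` gives 99%. Compound 2 thus stands second of the three, well apart from both neighbours. Among the measured compounds shown here, the only single-step change measured is a number 35 percentage points higher from compound 2 to compound 3 (beyond the scatter), which concerns a hydroxy group and not the bromine. Compound 4 `O=[N+]([O-])c1ccccc1CNc1cccc2[nH]ncc12` differs from compound 2 by hydrogen in place of bromo on an aromatic carbon. For the measured compounds named here, no measured step covers the loss of a bromine, so the direction can only be guessed from the small set. The step from compound 2 to compound 4 is expected to be a number 19 percentage points lower from compound 2 to compound 4 (beyond the scatter), and compound 4 is therefore estimated at 45%, with a likely range from 20% to 70%.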

Compound 4, a percentage reported as inhibition, at one concentration (the size of the read-out at that concentration, not a potency): 87%
Beside the measured number, compound 4's estimate is 42 percentage points below it; measured number outside the range, above it.
By their numbers in this assay, from the lowest: compound 1; then compound 2; then compound 4; then compound 3.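

In this assay, hydrogen in place of bromo on this aromatic carbon gives a number 23 percentage points higher from compound 2 to compound 4 (beyond the scatter). The bromine is therefore not needed for the effect at the concentration tested, and the compound without it reads higher. Nothing measured here accounts for this rise.

From the compounds shown here alone, it remains open how fluorine, a methoxy group or an amine at this position would compare with hydrogen. Also open, going by these compounds, is whether the hydroxy group that separates compound 3 from compound 2 would give a similar step on compound 4.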